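Chloromethylbenzyl purines: amino for chloro on a second core

This account rests on a few compounds, and the source may have more. Where it says the series, first, only, none or still open, it means among the compounds named here.

Measured in a functional assay on HOP-62 cells (Homo sapiens) for cytotoxicity, read by sulforhodamine B assay, with a stated time of 48 h; on this read-out higher numbers stand for weaker inhibition of growth and lower numbers for stronger inhibition of growth:
compound 1 `ClCc1ccccc1Cn1cnc2c(Cl)nc(Cl)nc21`: 2040 nM
compound 2 `ClCc1cccc(Cn2cnc3c(Cl)nc(Cl)nc32)c1`: 2290 nM
compound 3 `Nc1nc(Cl)c2ncn(Cc3ccccc3CCl)c2n1`: 21900 nM

Compounds 1 and 2 have the same atoms joined differently; the difference between the two cores is not broken down here, and their two values lie within the scatter of each other. Compound 3 carries amino in place of chloro on an aromatic carbon relative to compound 1, giving an 11-fold higher number from compound 1 to compound 3 (1.03 log units; beyond the scatter) in this assay.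

Compound 4 `Nc1nc(Cl)c2ncn(Cc3cccc(CCl)c3)c2n1` is not yet measured. It differs from compound 2 by amino in place of chloro on an aromatic carbon, the same change at the same place as from compound 1 to compound 3; it occurs twice in all here. Among the measured compounds shown here, for compound 4 a step of a 10-fold higher number from compound 2 to compound 4 (1.02 log units; beyond the scatter) in this assay is expected, because an 11-fold higher number from compound 1 to compound 3 (1.03 log units; beyond the scatter) is the only measured step of this change and sits well beyond the scatter. Compound 4 is therefore estimated at 24000 nM, between 9000 nM and 60000 nM.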

Compound 4, concentration for 50% growth inhibition: 5750 nM
For compound 4 the middle estimate is 4.2-fold (0.62 log units) above the measured one; measured number below the stated range.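

In this assay, amino in place of chloro on an aromatic carbon again gives weaker inhibition of growth, with a 2.5-fold higher number from compound 2 to compound 4 (0.40 log units; beyond the scatter), so the direction is shared by the two cores but the size is not: the same change on two cores in this assay, an 11-fold higher number (1.03 log units; beyond the scatter) from compound 1 to compound 3 and a 2.5-fold higher number (0.40 log units; beyond the scatter) from compound 2 to compound 4, 4.3-fold (0.63 log units) apart, beyond the scatter of two such steps

A step of this change measured on one core therefore gives its likely direction on the other, but not a dependable size. Among the compounds shown here, with only two pairs, this does not show what sets the size of the step, nor does it establish a rule beyond these compounds.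

Still open, from the compounds shown here alone, is how methoxy or methylamino would read at the same aromatic carbon in this assay. Also open, going by these compounds, is how hydroxymethyl in place of chloromethyl would read on either core.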